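The compounds below may be only part of what the source reports. "The series", "measured", "known", "first", "only" and "open" are said of these compounds alone.

In a functional assay on A549 cells (Homo sapiens) for inhibition, read by MTT assay, with a stated time of 48 h (a lower number here means a stronger inhibitor, a higher number a weaker inhibitor), compound 1 `COc1cc(NC(=O)Nc2ccccn2)cc(-c2cccnc2)c1OC` gives 13500 nM and compound 2 `COc1ccc(-c2cc(NC(=O)Nc3ccccn3)cc(OC)c2OC)cn1` gives 24700 nM so these two numbers lie within the scatter of each other. Compound 3 `COc1cc(NC(=O)Nc2ccccn2)cc(-c2c[nH]cn2)c1OC` is still unmeasured and differs from compound 2 in one group 1H-imidazol-4-yl in place of 6-methoxypyridin-3-yl on an aromatic carbon with 1H-imidazol-4-yl in place of 6-methoxypyridin-3-yl on an aromatic carbon. For the measured compounds named here, one measured step bears on this group: methoxy in place of hydrogen on an aromatic carbon gave a 1.8-fold higher number from compound 1 to compound 2 (0.26 log units; within the scatter) and so stayed within the scatter. Going by the values given here, that step says little about a five-membered aromatic ring, and no measured compound carries one at this place. No step beyond the scatter is therefore expected in either direction, though this expectation rests on thin evidence. The estimated step is a 1.4-fold lower number from compound 2 to compound 3 (0.14 log units; within the scatter) for now. For compound 3 the expected value is 18000 nM with an estimated range of 6000 nM to 50000 nM in this measurement.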

Compound 3, half-maximal inhibitory concentration: 14100 nM
Estimate against measurement, compound 3: 1.3-fold (0.11 log units) above; low and high end bracket the measured number.
By their numbers in this assay, from the lowest: compounds 1, 3 and 2 (each within the scatter of the next).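

In this assay, this place on the core tolerates a five-membered aromatic ring as well as a six-membered one: 1H-imidazol-4-yl in place of 6-methoxypyridin-3-yl gave a 1.8-fold lower number from compound 2 to compound 3 (0.24 log units; within the scatter) and 1H-imidazol-4-yl in place of pyridin-3-yl gave a 1.0-fold higher number from compound 1 to compound 3 (0.02 log units; within the scatter). Neither the smaller ring nor its hydrogen-bond donor, which 6-methoxypyridin-3-yl lacks, moved the number beyond the scatter. Nothing available explains why these changes leave the number within the scatter. On these data alone, all the groups compared at this place are aromatic rings, so it remains open how a group such as an amine, a carboxylic acid or a longer chain would behave there. As far as these compounds go, whether any change at this place can produce a step beyond the scatter also remains open.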